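The source may report more compounds than this note shows. Statements on the series, on what has been measured and on what is new or still open speak of the compounds shown alone.

Compound 1 `CC(C)(C)C/N=C(/NC#N)Nc1cccnc1` and compound 2 `CC(/N=C(/NC#N)Nc1cccnc1)C(C)(C)C` share one core; compound 3 `CC(C)(C)N/C(=N\O)Nc1cccnc1` and the unmeasured compound 4 `CCC(C)(C)N/C(=N\O)Nc1cccnc1` share another, and the difference between the two cores is not broken down here. In a functional assay on the whole organism (blood, strain Wistar-Okamoto) with Rattus norvegicus as the target, with a stated time of 5 days (a lower number here means that less compound is needed, a higher number that more compound is needed for the effect), compound 1 gives 2.5 mg/kg, and compound 2 gives 1 mg/kg. The step of a 2.5-fold lower number from compound 1 to compound 2 (0.40 log units; beyond the scatter) comes from methyl in place of hydrogen on a saturated chain carbon bound to a double-bonded nitrogen and a saturated chain carbon. In this assay compound 3 gives only a limit, > 35 mg/kg. Compound 4 carries the same kind of change, (methyl in place of hydrogen on a saturated chain carbon, two bonds along the chain from an amine nitrogen); the place differs, being two bonds along the chain from an amine nitrogen rather than bound to a double-bonded nitrogen and a saturated chain carbon. Going by the values given here, because compound 3 sits at the limit of > 35 mg/kg in this assay, at which 1 of the 3 values shown sits, any number for compound 4 rests on a limit, and the measured step between compound 1 and compound 2 is the only guide to its size. The step expected from compound 3 to compound 4 is a step that the limit leaves unreadable from compound 3 to compound 4, set beside the measured one. Compound 4 is estimated at 40 mg/kg, expected between 14 mg/kg and 120 mg/kg, with a fair chance that only a limit is reported again.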

Compound 4, minimum effective dose: > 20 mg/kg
Compound 4 gave a limit, no number (the forecaster's own chance of this, stated with the estimate: 70%); the middle value does not contradict the limit.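

In this assay compound 3 gives only a limit, > 35 mg/kg. Going by these compounds alone, compound 4 also gives only a limit, > 20 mg/kg, so no step between compound 3 and compound 4 can be read. The compounds shown leave open whether methyl in place of hydrogen at this place on the chain changes the minimum effective dose on this core, and by how much.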